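Varying the amide substituent on a shared core

A few compounds are considered here, and "the series" means these few. Any claim that something is new, unique, unknown or untested is made for them only; others in the source may bear on it.

Compound 1 `CCCCCCCCNC(=O)/C=C/c1c(/C=C/c2ccc(OC)cc2)cc(OC)cc1OC` carries an octylamino group on the carbonyl and in a functional assay on A549 cells (Homo sapiens) for inhibition, read by MTT assay, with a stated time of 48 h (on this read-out lower numbers stand for stronger inhibition and higher numbers for weaker inhibition), gives 8660 nM, the highest number of the three measured compounds. Compound 2 `CCCCNC(=O)/C=C/c1c(/C=C/c2ccc(OC)cc2)cc(OC)cc1OC` gives 1880 nM in this assay, and compound 3 `COc1ccc(/C=C/c2cc(OC)cc(OC)c2/C=C/C(=O)NC(C)C)cc1` gives 2360 nM. Both measured steps start from compound 1 and cut down the amide substituent: a 4.6-fold lower number from compound 1 to compound 2 (0.66 log units; beyond the scatter) and a 3.7-fold lower number from compound 1 to compound 3 (0.56 log units; beyond the scatter), each beyond the scatter. Between compound 2 and compound 3 the step is a 1.3-fold higher number from compound 2 to compound 3 (0.10 log units; within the scatter), within the scatter.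

Compound 4 `COc1ccc(/C=C/c2cc(OC)cc(OC)c2/C=C/C(=O)N2CCC(c3ccccc3)CC2)cc1` differs from compound 1 by 4-phenylpiperidin-1-yl in place of octylamino on a carbonyl carbon. The measured steps bear on it only loosely: they show that trimming the amide substituent lowers the number, but none removes the amide hydrogen or places rings on the nitrogen. Because compound 1 sits at 8660 nM and both departures from it, a 4.6-fold lower number from compound 1 to compound 2 (0.66 log units; beyond the scatter) and a 3.7-fold lower number from compound 1 to compound 3 (0.56 log units; beyond the scatter), went downward, a modest downward move is expected for compound 4, with wide uncertainty. The expected step is a 1.9-fold lower number from compound 1 to compound 4 (0.28 log units; within the scatter). Compound 4 is estimated at 4500 nM, within 1200 nM to 16000 nM.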

Compound 4, half-maximal inhibitory concentration: 6690 nM
Compound 4: the middle estimate sits 1.5-fold (0.17 log units) below what was measured, within the range that was stated.
By their numbers in this assay, from the lowest: compounds 2 and 3 (each within the scatter of the next); then compounds 4 and 1 (each within the scatter of the next).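

Swapping octylamino for 4-phenylpiperidin-1-yl on this carbonyl carbon gives a 1.3-fold lower number from compound 1 to compound 4 (0.11 log units; within the scatter), so a group with two six-membered rings and no hydrogen-bond donor reads the same as the octyl chain in this assay. Against the shorter substituents the same group lies beyond the scatter, at a 2.8-fold higher number from compound 3 to compound 4 (0.45 log units; beyond the scatter) and a 3.6-fold higher number from compound 2 to compound 4 (0.55 log units; beyond the scatter), and the lowest numbers in the series stay with isopropylamino and butylamino. No measurement on hand accounts for these differences.

The ring system and the loss of the amide hydrogen arrive together in this change, and their separate contributions remain unresolved. Plain piperidin-1-yl, or a butylamino chain ending in a carboxylic acid, would be useful further points of comparison on this carbonyl carbon.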